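Swapping a small group for a larger one on compound 1

A few compounds are considered here, and "the series" means these few. Any claim that something is new, unique, unknown or untested is made for them only; others in the source may bear on it.

Four related compounds are considered here, three of them already tested. In a functional assay on FM3A cells (Mus musculus) for cytotoxicity, read by cell counting, with a stated time of 2 days (a higher number here means a weaker inhibitor, a lower number a stronger inhibitor), compound 1 `CCN1C(=O)S/C(=C\c2ccc(N)cc2)C1=O` gives 76000 nM, the highest of the three numbers shown, so it is the weakest of the measured compounds. Compound 2 `C=C(Br)C(=O)Nc1cccc(/C=C2\SC(=O)N(Cc3ccc(C)cc3)C2=O)c1` gives 1000 nM in this assay, and compound 3 `C=C(Br)C(=O)Nc1ccc(/C=C2\SC(=O)N(C)C2=O)cc1` gives 750 nM; both lie far below compound 1, beyond the scatter, and the two differ from compound 1 in more than one place, so their numbers alone show only that they are much stronger. Compound 4 `Cc1ccc(CN2C(=O)S/C(=C\c3ccc(N)cc3)C2=O)cc1` is the untested one. It differs from compound 1 by a single change: 4-methylphenyl in place of methyl on a saturated chain carbon bound to an amide-type nitrogen in a ring. Compound 2 and compound 3 carry the same two groups at that position and their numbers lie close together, which suggests that this change alone moves the number only a little. A small step downward, within or just beyond the scatter, is expected in this assay, as a 2.5-fold lower number from compound 1 to compound 4 (0.40 log units; beyond the scatter). Compound 4 is therefore estimated at 30000 nM, with a range from 8000 nM to 100000 nM.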

Compound 4, half-maximal inhibitory concentration: > 250000 nM
Compound 4 gave a limit, no number; the forecaster's own chance of this, stated with the estimate: 10%; middle value at least 8.3-fold (0.92 log units) away from the limit.
By their numbers in this assay, from the lowest: compounds 3 and 2 (each within the scatter of the next); then compound 1. At a limit, above all of these: compound 4.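

In this assay, putting 4-methylphenyl in place of methyl on a saturated chain carbon bound to an amide-type nitrogen in a ring gives an at least 3.2-fold higher number from compound 1 to compound 4 (0.51 log units; beyond the scatter), so the larger group goes with a weaker compound here. Among these compounds, compound 2 and compound 3 each differ from compound 1 in more than one place, so this pair is the first to isolate the position. Compound 4 gave a limit and not a number, so the full size of the step stays unknown: the limit of > 250000 nM in this assay, at which 1 of the 4 values shown sits.

Still open is whether the whole ring or its methyl matters, as the compounds shown include neither a plain phenyl nor a longer chain such as butyl at this position. Also open, going by these compounds, is whether the change acts alike on compounds carrying the bromine-bearing amide of compound 2 and compound 3.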